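This account rests on a few compounds, and the source may have more. Where it says the series, first, only, none or still open, it means among the compounds named here.

In a physicochemical assay for solubility, using the shake flask method, in simulated intestinal fluid, measured as kinetic solubility, with a stated time of 20 h, at pH 6.5 (on this read-out lower numbers stand for lower solubility and higher numbers for higher solubility), compound 1 (`FC(F)(F)c1ccc(Nc2cc3[nH]c(-c4cccc(C(F)(F)F)c4)nc3cn2)nc1`) reads >= 50000 nM, which is a limit and not a number. Compound 2 (`Fc1ccc(Nc2cc3[nH]c(-c4ccc(F)c(F)c4)nc3cn2)nc1`) reads >= 50000 nM, which is also a limit. For the measured compounds named here, compound 3 (`FC(F)(F)c1ccc(Nc2cc3[nH]c(C4CCCC4)nc3cn2)nc1`) gives 85000 nM, the only true number of the three. Compound 4 (`FC(F)(F)c1ccc(Nc2cc3[nH]c(C4CCOC4)nc3cn2)nc1`) carries oxolan-3-yl in place of cyclopentyl on an aromatic carbon. The swap adds a hydrogen-bond acceptor and keeps the count of heavy atoms. Going by the values given here, the one measured step that changes this same group is a step that the limit leaves unreadable from compound 1 to compound 3, so it offers no size to carry over. With no readable size to go on, no step beyond the usual scatter is expected in this assay, and the estimated step is a 1.1-fold higher number from compound 3 to compound 4 (0.02 log units; within the scatter). For compound 4 the expected value is 90000 nM, with an estimated range from 55000 nM to 140000 nM.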

Compound 4, solubility: 180000 nM
Compound 4: middle estimate off by 2.0-fold (0.30 log units), on the low side; measured number outside the range, above it.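

In this assay, for the compounds shown here, oxolan-3-yl in place of cyclopentyl gives a 2.1-fold higher number from compound 3 to compound 4 (0.33 log units; beyond the scatter), the first readable step at this place, on an aromatic carbon between two ring nitrogen atoms. The two rings have the same count of heavy atoms, yet oxolan-3-yl brings an oxygen and a hydrogen-bond acceptor, and even this small swap moves the read-out. The steps from compound 1 cannot be read: the limit of >= 50000 nM in this assay, at which 2 of the 4 values shown sit.

This rests on a single pair of compounds. From the compounds shown here alone, whether an amine such as pyrrolidin-3-yl, or an open chain such as 2-methoxyethyl, would move the number in the same way remains open.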